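This account rests on a few compounds, and the source may have more. Where it says the series, first, only, none or still open, it means among the compounds named here.

Working notes on the series. Among the compounds with values here, compound 1 `CNC(=O)c1ccccc1-c1ccc([C@@H](C)Nc2nccc(C)c2NC(=O)CC(F)(F)F)cc1` and compound 2 `COC(=O)c1ccccc1-c1ccc(CNc2nccc(C)c2NC(=O)CC(F)(F)F)cc1` share one core and differ in two places, so no single step between them can be isolated. In an ADME assay (Rattus norvegicus, strain Sprague Dawley) for metabolic stability (a lower number here means that the compound disappears faster, a higher number that the compound lasts longer), compound 1 gives 0.5 h. In this assay compound 2 gives 0.4 h. Of the two numbers, compound 2 sits at the low end, yet compound 1 lies within the scatter of it, so the two compounds cannot be told apart on these data.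

Compound 3 `COC(=O)c1ccccc1-c1ccc([C@@H](C)Nc2nccc(C)c2NC(=O)CC(F)(F)F)cc1` has not yet been measured. It differs from compound 2 by methyl in place of hydrogen on a saturated chain carbon bound to an aromatic carbon and a nitrogen on an aromatic ring. Within the data shown here, compound 1 already carries this methyl, but it also differs from compound 2 elsewhere, so no measured step tells what the methyl alone does. Because compound 1 gives 0.5 h and compound 2 gives 0.4 h, no step beyond the scatter is expected here; the expected step is a 1.3-fold higher number from compound 2 to compound 3 (0.10 log units; within the scatter). Compound 3 is estimated at 0.5 h, with a range from 0.25 h to 1 h.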

Compound 3, half-life: 0.9 h
Estimate against measurement, compound 3: 1.8-fold (0.26 log units) below, within the range that was stated.
By their numbers in this assay, from the lowest: compounds 2, 1 and 3 (each within the scatter of the next, the first and the last beyond it).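

Within the data shown here, with the methyl isolated for the first time, this assay shows a 2.3-fold higher number from compound 2 to compound 3 (0.35 log units; beyond the scatter) for methyl in place of hydrogen on a saturated chain carbon bound to an aromatic carbon and a nitrogen on an aromatic ring, a modest step beyond the scatter. On the carbonyl carbon, methoxy in place of methylamino gives a 1.8-fold higher number from compound 1 to compound 3 (0.26 log units; within the scatter) and stays within the scatter, so these two groups cannot be told apart here in the presence of the methyl. Nothing available explains the methyl step.

From the compounds shown here alone, whether the methyl step also holds with methylamino on the carbonyl carbon remains open. Also open, going by these compounds, is how a longer chain such as ethyl at the saturated chain carbon, or a carboxylic acid in place of the methyl ester, would behave.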